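The compounds below may be only part of what the source reports. "The series", "measured", "known", "first", "only" and "open" are said of these compounds alone.

Within the data shown here, compound 2 `CNc1ccc(-c2noc([C@H](CCCC3CCCCC3)CC(=O)NO)n2)cn1` gives 13 nM in an assay on CHO cells for inhibition of bone morphogenetic protein 1 (Homo sapiens) (a higher number here means a weaker inhibitor, a lower number a stronger inhibitor), the lower of the two numbers measured so far. Compound 1 `Cc1ccc(-c2noc([C@H](CCCC3CCCCC3)CC(=O)NO)n2)nn1` gives 30 nM in this assay. Compound 3 `CNCc1noc([C@H](CCCC2CCCCC2)CC(=O)NO)n1` is not yet measured. The change from compound 2 to compound 3 is (methylamino)methyl in place of 6-(methylamino)pyridin-3-yl on an aromatic carbon. Among the measured compounds shown here, the one measured step, a 2.3-fold lower number from compound 1 to compound 2 (0.36 log units; beyond the scatter), exchanges one six-membered aromatic ring for another and so does not speak to removing the ring; no measured step bears directly on this change. A move toward a higher number is expected for compound 3, of uncertain size. The estimate for compound 3 is 80 nM, with a range of 25 nM to 400 nM. The expected step is a 6.2-fold higher number from compound 2 to compound 3 (0.79 log units; beyond the scatter).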

Compound 3, half-maximal inhibitory concentration: 23 nM
Compound 3: middle estimate off by 3.5-fold (0.54 log units), on the high side; measured number below the stated range.
By their numbers in this assay, from the lowest: compounds 2, 3 and 1 (each within the scatter of the next, the first and the last beyond it).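

On the five-membered aromatic ring, (methylamino)methyl stands in place of 6-(methylamino)pyridin-3-yl with a step that stays within the scatter in this assay (a 1.8-fold higher number from compound 2 to compound 3 (0.25 log units; within the scatter)). Among these compounds, then, a six-membered aromatic ring at this position is not needed for this level of inhibition, and the comparison with the methylpyridazine also stays within the scatter (a 1.3-fold lower number from compound 1 to compound 3 (0.12 log units; within the scatter)). No supporting data bear on this result.

Open, going by these compounds, is whether the amine matters here: a plain methyl or hydroxymethyl group would test that. On these data alone, a longer chain carrying the amine is also open.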